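Swapping Isopropyl for an Ester-Bearing Chain on Compound 2

The source may hold more compounds than are shown below. What is called first, only, known or untested is meant among the compounds shown, and "the series" means these compounds.

Compound 2 `CC(C)n1nc(-c2cccnc2)c2ccccc2c1=O` is one of three close relatives sharing a core. In an assay on isolated protein (Oryctolagus cuniculus) with Thromboxane-A synthase (Homo sapiens) as the target, tested at 1 uM (on this read-out higher numbers stand for more inhibition at the one concentration tested (going by the name of the read-out) and lower numbers for less inhibition), compound 2 gives 87%, and compound 1 `CCn1nc(-c2cccnc2)c2ccccc2c1=O` gives 87%; the two are level, and together they are the highest of the three numbers, as the step of no change at the digits printed from compound 1 to compound 2 (within the scatter) shows. Compound 3 `CC(=O)OCCn1nc(-c2cccnc2)c2ccccc2c1=O` gives 32%, a large fall a number 55 percentage points lower from compound 2 to compound 3 (beyond the scatter) and equally a number 55 percentage points lower from compound 1 to compound 3 (beyond the scatter).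

Compound 4 `CCOC(=O)Cn1nc(-c2cccnc2)c2ccccc2c1=O` has not yet been measured. Its change from compound 2 is (ethoxycarbonyl)methyl in place of isopropyl on an aromatic nitrogen. The step that bears on it is a number 55 percentage points lower from compound 2 to compound 3 (beyond the scatter), where a chain carrying an ester likewise replaced isopropyl, so a sizeable drop is expected for compound 4, estimated as a number 42 percentage points lower from compound 2 to compound 4 (beyond the scatter). Compound 4 is therefore expected to give about 45%, between 20% and 75%.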

Compound 4, a percentage reported as inhibition, at one concentration (the size of the read-out at that concentration, not a potency): 28%
For compound 4 the middle estimate is 17 percentage points above the measured one; the range from low to high includes it.
By their numbers in this assay, from the lowest: compounds 4 and 3 (each within the scatter of the next); then compounds 1 and 2 (each within the scatter of the next).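

The fall (a number 59 percentage points lower from compound 2 to compound 4 (beyond the scatter)) and the equal one (a number 59 percentage points lower from compound 1 to compound 4 (beyond the scatter)) show that the low number of compound 3 is not a one-off: a second ester-bearing chain on this aromatic nitrogen also ends far down in this assay. The way the ester sits in the chain makes no readable difference (a number 4 percentage points lower from compound 3 to compound 4 (within the scatter)), since (ethoxycarbonyl)methyl and the 2-acetoxyethyl chain stay within the scatter of each other. Nothing measured here explains the fall.

The compounds shown leave open whether the fall belongs to the ester itself or to the length of the chain. A plain butyl chain, a carboxylic acid or an amine on this nitrogen would speak to that.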